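Toward a biphenylmethyl ester on the dihydropyridine series

The source may report more compounds than this note shows. Statements on the series, on what has been measured and on what is new or still open speak of the compounds shown alone.

Compound 2 `COC(=O)C1=C(C)NC(C)=C(C(=O)OCC2CC2)C1c1cccc([N+](=O)[O-])c1` gives 21 nM in a functional assay on HEK293 cells for antagonist activity at Voltage-dependent L-type calcium channel subunit alpha-1D (Rattus norvegicus), read by FLIPR (on this read-out higher numbers stand for weaker inhibition and lower numbers for stronger inhibition), the higher of the two measured numbers; compound 1 `C=CCOC(=O)C1=C(C)NC(C)=C(C(=O)OC)C1c1ccccc1[N+](=O)[O-]` gives 10 nM in this assay, a lower number by a margin beyond the scatter. Compound 3 `COC(=O)C1=C(C)NC(C)=C(C(=O)OCc2ccc(-c3ccccc3)cc2)C1c1cccc([N+](=O)[O-])c1` has not yet been measured. It differs from compound 2 in one place: 4-phenylphenyl in place of cyclopropyl on a saturated chain carbon bound to an oxygen next to a carbonyl group. Among the compounds with values here, no comparable step among measured compounds exists, so the expected step from compound 2 to compound 3 is uncertain; a small change, likely within the scatter, is expected, a 1.4-fold higher number from compound 2 to compound 3 (0.15 log units; within the scatter). For compound 3 the estimate in this assay is 30 nM, within the range 8 nM to 120 nM.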

Compound 3, half-maximal inhibitory concentration: 74 nM
For compound 3 the middle estimate is 2.5-fold (0.39 log units) below the measured one; measured number inside the range.
By their numbers in this assay, from the lowest: compound 1; then compound 2; then compound 3.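

In this assay, 4-phenylphenyl in place of cyclopropyl on a saturated chain carbon bound to an oxygen next to a carbonyl group gives a 3.5-fold higher number from compound 2 to compound 3 (0.55 log units; beyond the scatter), a modest loss of inhibition. This position therefore responds to the exchange, yet a group of 12 heavy atoms in place of one of 3 still leaves measurable inhibition. No available evidence explains the step. The compounds shown leave open whether a single phenyl ring, a longer chain or an amine at this place would fall nearer compound 2 or compound 3.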